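The compounds below may be only part of what the source reports. "The series", "measured", "known", "first", "only" and "open" are said of these compounds alone.

Among the compounds with values here, in an ADME assay on DU-145 cells (Homo sapiens) for cytotoxicity, read by MTT assay, with a stated time of 72 h (on this read-out lower numbers stand for stronger inhibition and higher numbers for weaker inhibition), compound 2 (`COc1ccc(C2=C(c3cc(OC)c(OC)c(OC)c3)C(=O)C(OC(C)=O)C2)cc1F`) gives 16 ug/mL as the only actual number so far. Compound 1 (`C=CCOc1cc(C2=C(c3cc(OC)c(OC)c(OC)c3)C(=O)C(O)C2)ccc1OC`) stands at > 100 ug/mL as a limit of the assay and not a number. Compound 3 (`COc1ccc(C2=C(c3cc(OC)c(OC)c(OC)c3)C(=O)C(O)C2)cc1F`) comes from compound 2 through hydrogen in place of acetyl on an oxygen on a saturated carbon in a single place, acetoxy to hydroxy. Compound 1, also a hydroxy compound though different elsewhere, reads > 100 ug/mL as a limit, so weaker inhibition is expected in this assay for the new compound. The expected step is a 2.2-fold higher number from compound 2 to compound 3 (0.34 log units; beyond the scatter) and would be moderate and upward. For compound 3 the estimate is 35 ug/mL with an expected range of 10 ug/mL to 100 ug/mL in this read-out.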

Compound 3, half-maximal inhibitory concentration: 27 ug/mL
For compound 3 the middle estimate is 1.3-fold (0.11 log units) above the measured one, within the range that was stated.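

In this assay the change on the oxygen shows a 1.7-fold higher number from compound 2 to compound 3 (0.23 log units; within the scatter), so acetoxy and hydroxy read alike at this position. With the hydroxy kept, fluoro in place of allyloxy on an aromatic carbon gives an at least 3.7-fold lower number from compound 1 to compound 3 (0.56 log units; beyond the scatter), a step that, unlike the first, lies beyond the scatter. Its true size stays unknown, since compound 1 reads as a limit and not a number: the limit of > 100 ug/mL in this assay, at which 1 of the 3 values shown sits.

As far as these compounds go, whether an amine or a longer ester chain on this oxygen would also read alike remains open. So does whether acetoxy and hydroxy would still read alike with allyloxy on the aromatic ring.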